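Cyclohexyl in place of chloro: compound 1 to compound 4

The source may report more compounds than this note shows. Statements on the series, on what has been measured and on what is new or still open speak of the compounds shown alone.

Measured compounds:
- compound 1 `[O-][n+]1ccc(Cl)c(Oc2ccccc2)c1`, > 300 mg/kg (a limit)
- compound 2 `Cc1cc[n+]([O-])cc1Oc1ccc(Cl)cc1`, 100 mg/kg
- compound 3 `COc1ccc(Oc2c[n+]([O-])ccc2C)cc1`, 300 mg/kg

Among the compounds with values here, in a functional assay on the whole organism with Mus musculus as the target, in the maximal electroshock model, with a stated time of 30 min (on this read-out lower numbers stand for an effect already at smaller amounts and higher numbers for an effect only at larger amounts of compound), compound 2 gives 100 mg/kg and compound 3 gives 300 mg/kg; the single measured step, a 3.0-fold higher number from compound 2 to compound 3 (0.48 log units; beyond the scatter), is the only change in this assay with a number on both sides. Within the data shown here, compound 1 stands apart: in this assay compound 1 gives only a limit, > 300 mg/kg, so its true value is not known and no measured step can be drawn from it. the limit of > 300 mg/kg in this assay, at which 1 of the 3 values shown sits, marks that limit as the one value of the three that is not a number.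

Compound 4 `[O-][n+]1ccc(C2CCCCC2)c(Oc2ccccc2)c1` differs from compound 1 by cyclohexyl in place of chloro on an aromatic carbon. Among the measured compounds shown here, no measured step concerns cyclohexyl, and the one step that exchanges chloro, methoxy in place of chloro, was modest. There is therefore no ground to expect a step beyond the scatter in this assay, only the uncertainty of starting from a limit. The estimate for compound 4 is 300 mg/kg, expected to fall between 100 mg/kg and 1000 mg/kg. The expected step is a number no higher from compound 1 to compound 4 (the limit leaves the size open).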

Compound 4, minimum effective dose: > 300 mg/kg
Compound 4 gave a limit, no number (the forecaster's own chance of this, stated with the estimate: 50%); the middle value sits exactly at the limit.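

Compound 1 and compound 4 both give only a limit in this assay, so no step between them can be read: the limit of > 300 mg/kg in this assay, at which 2 of the 4 values shown sit.

The compounds shown leave open what number either compound would give, and whether cyclohexyl in place of chloro changes the minimum effective dose at all.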